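Estimating compound 4 from its measured neighbours

This account rests on a few compounds, and the source may have more. Where it says the series, first, only, none or still open, it means among the compounds named here.

Three compounds were tested in an ADME assay on microsomes from liver (Homo sapiens) for metabolic stability, with a stated time of 10 min; on this read-out lower numbers stand for a less stable compound and higher numbers for a more stable compound:
Compound 1 `CC[C@]1(C(=O)O)CC[C@H](C(=O)N2CC[C@](c3ccc(C(F)(C(F)(F)F)C(F)(F)F)cc3)(S(=O)(=O)c3ccc(F)cc3)C2)CC1`: 100%
Compound 2 `C[C@]1(C(=O)N2CC[C@](c3ccc(C(F)(C(F)(F)F)C(F)(F)F)cc3)(S(=O)(=O)c3ccc(F)cc3)C2)CC[C@H](C(=O)O)CC1`: 80%
Compound 3 `O=C(C1CCS(=O)(=O)C1)N1CC[C@](c2ccc(C(F)(C(F)(F)F)C(F)(F)F)cc2)(S(=O)(=O)c2ccc(F)cc2)C1`: 100%; 100% (2 entries)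

Compound 1 stands at the top of the two single numbers; compound 2 lies below it by a number 20 percentage points lower from compound 1 to compound 2 (beyond the scatter), a modest step, while compound 3 returned two entries, both at the top as well. Compound 4 `O=C(N1CC[C@](c2ccc(C(F)(C(F)(F)F)C(F)(F)F)cc2)(S(=O)(=O)c2ccc(F)cc2)C1)C1(CO)CCS(=O)(=O)CC1` differs from compound 1 in one place: 4-(hydroxymethyl)-1,1-dioxothian-4-yl in place of 4-carboxy-4-ethylcyclohexyl on a carbonyl carbon. Within the data shown here, the only measured step at this position is a number 20 percentage points lower from compound 1 to compound 2 (beyond the scatter), which was small. Compound 3 also carries a ring in which sulfur bears two oxygens, and its values are high. Compound 4 is therefore expected to change by a number 8 percentage points lower from compound 1 to compound 4 (within the scatter), little or nothing beyond the scatter. The estimate for compound 4 is 92%, between 72% and 100%.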

Compound 4, percent of the compound remaining: 75%
Compound 4: the middle estimate sits 17 percentage points above what was measured; measured number inside the range.
By their numbers in this assay, from the lowest: compounds 4 and 2 (each within the scatter of the next); then compound 1.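

In this assay, putting 4-(hydroxymethyl)-1,1-dioxothian-4-yl on the carbonyl carbon gives a number 25 percentage points lower from compound 1 to compound 4 (beyond the scatter), so among the three groups compared here, 4-carboxy-4-ethylcyclohexyl alone stands apart. The same swap made against 4-carboxy-1-methylcyclohexyl gives a number 5 percentage points lower from compound 2 to compound 4 (within the scatter), so these two groups cannot be told apart in this read-out. Nothing measured here explains either step.

Going by these compounds, compound 4 alters the ring and its substituent together, so which of them matters stays open. Also open, on these data alone, is how the number would respond to an amine in place of the hydroxymethyl.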